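Piling Chlorines onto an Acrylamide Warhead

The compounds below may be only part of what the source reports. "The series", "measured", "known", "first", "only" and "open" are said of these compounds alone.

For the measured compounds named here, compound 2 `C=C(Cl)C(=O)Nc1cc(Nc2nccc(-c3cn(C)c4ccccc34)n2)c(OC)cc1N(C)CCN(C)C` gives 7520 nM in a functional assay on A549 cells (Homo sapiens) for antiproliferative activity, read by MTT assay, with a stated time of 72 h (a higher number here means a weaker inhibitor, a lower number a stronger inhibitor), the higher of the two numbers measured so far; its nearest neighbour, compound 1 `C=C(F)C(=O)Nc1cc(Nc2nccc(-c3cn(C)c4ccccc34)n2)c(OC)cc1N(C)CCN(C)C`, gives 2460 nM. Going by the values given here, that single step a 3.1-fold higher number from compound 1 to compound 2 (0.49 log units; beyond the scatter) is the only measured change. Compound 3 `COc1cc(N(C)CCN(C)C)c(NC(=O)C(Cl)=C(Cl)Cl)cc1Nc1nccc(-c2cn(C)c3ccccc23)n1` carries a further change of the same kind: 1,2,2-trichloroethenyl in place of 1-chloroethenyl on a carbonyl carbon. Among the compounds with values here, no measured step covers two extra chlorines on this chain, so the expectation rests on compound 1 and compound 2 alone. For compound 3 the number is expected to rise again, a step of a 2.0-fold higher number from compound 2 to compound 3 (0.30 log units; within the scatter), giving an estimate of 15000 nM within a range from 5000 nM to 50000 nM.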

Compound 3, half-maximal inhibitory concentration: > 50000 nM
Compound 3: a limit, no number; the forecaster's own chance of this, stated with the estimate: 15%; middle value at least 3.3-fold (0.52 log units) away from the limit.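

In this assay, compound 3 sits at a limit of the assay, not at a number: the limit of > 50000 nM in this assay, at which 1 of the 3 values shown sits. Replacing 1-chloroethenyl with 1,2,2-trichloroethenyl on this carbonyl carbon gives an at least 6.6-fold higher number from compound 2 to compound 3 (0.82 log units; beyond the scatter), and the full change from 1-fluoroethenyl gives an at least 20-fold higher number from compound 1 to compound 3 (1.30 log units; beyond the scatter). This position therefore allows more than the modest shift seen earlier: with this chain, antiproliferative activity falls out of the measurable range.

Going by these compounds, how far compound 3 lies past the limit stays unknown. Also open, on these data alone, is what a plain ethenyl group without halogen or a 1-methylethenyl group would give here.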